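Two benzylamine ureas and the diethylamino change

The source may report more compounds than this note shows. Statements on the series, on what has been measured and on what is new or still open speak of the compounds shown alone.

Compound 1 `CN(C)Cc1ccc(NC(=O)NN=C(c2ccccn2)c2ccccn2)cc1` and compound 2 `CCN(CC)Cc1ccc(NC(=O)NN=C(c2ccccn2)c2ccccn2)cc1` share a core, and compound 3 `CN(C)Cc1ccc(NC(=O)NN=C(c2ccccc2)c2ccccc2)cc1` carries a different one; the difference between the two cores is not broken down here. In a functional assay on MCF7 cells (Homo sapiens) for antiproliferative activity, read by CCK-8 assay, with a stated time of 24 h (a higher number here means a weaker inhibitor, a lower number a stronger inhibitor), compound 1 gives > 40000 nM, which is a limit of the assay and not a number. In this assay compound 2 gives > 40000 nM, again a limit. The change from compound 1 to compound 2 is diethylamino in place of dimethylamino on a saturated chain carbon bound to an aromatic carbon; its step in this assay is a step that the two limits leave unreadable from compound 1 to compound 2, because the limit of > 40000 nM in this assay, at which 2 of the 3 values shown sit, hides any difference. In this assay compound 3 gives 12100 nM. Compound 4 `CCN(CC)Cc1ccc(NC(=O)NN=C(c2ccccc2)c2ccccc2)cc1` has not yet been measured; it differs from compound 3 by diethylamino in place of dimethylamino on a saturated chain carbon bound to an aromatic carbon, the same change as before. Since that change left no readable step, compound 4 is expected to sit near compound 3, with an estimated step of a 1.2-fold higher number from compound 3 to compound 4 (0.09 log units; within the scatter). Compound 4 is estimated at 15000 nM in this assay, expected between 6000 nM and 40000 nM.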

Compound 4, half-maximal inhibitory concentration: 13100 nM
Compound 4: the middle estimate sits 1.1-fold (0.06 log units) above what was measured; the measured number falls inside the stated range.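

In this assay, putting diethylamino in place of dimethylamino gives a 1.1-fold higher number from compound 3 to compound 4 (0.03 log units; within the scatter), so on the core of compound 3 the two amines cannot be told apart. The same change on the core of compound 1 gives no readable step, because both compounds of that pair sit at a limit of the assay, which is not a number: the limit of > 40000 nM in this assay, at which 2 of the 4 values shown sit. This gives one readable case of the change on one core, and it does not show that the change behaves alike on the other core.

Going by these compounds, it remains open how dipropylamino, with longer chains on the nitrogen, would read on a saturated chain carbon bound to an aromatic carbon. On these data alone, a carboxylic acid in that place is equally open in this assay.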